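The source may report more compounds than this note shows. Statements on the series, on what has been measured and on what is new or still open speak of the compounds shown alone.

Two esters have been measured so far. Compound 1 (`COC(=O)c1cc(N2C(=O)C3=C(CCCC3)C2=O)ccc1Cl`) gives 1620 nM in a functional assay on the whole organism with Scenedesmus acutus as the target, with a stated time of 20 h (a lower number here means a stronger inhibitor, a higher number a weaker inhibitor), and holds the lower number. Compound 2 (`CCCCCOC(=O)c1cc(N2C(=O)C3=C(CCCC3)C2=O)ccc1Cl`) gives 5370 nM in this assay and holds the higher of the two numbers. Compound 3 (`CCCCCCCCOC(=O)c1cc(N2C(=O)C3=C(CCCC3)C2=O)ccc1Cl`) extends the chain of compound 2 (propyl in place of hydrogen on a saturated chain carbon, five bonds along the chain from an oxygen next to a carbonyl group) with propyl in place of hydrogen on a saturated chain carbon, five bonds along the chain from an oxygen next to a carbonyl group. Within the data shown here, only one measured step bears on this change: the modest rise (a 3.3-fold higher number from compound 1 to compound 2 (0.52 log units; beyond the scatter)) that accompanies a longer chain. A single step sets no trend, so its size is a rough guide only, but a further modest step towards a higher number is expected. The estimated step is a 2.2-fold higher number from compound 2 to compound 3 (0.35 log units; beyond the scatter) in this assay on that basis. For compound 3 the expected value is 12000 nM with an estimated range of 5000 nM to 35000 nM in this assay.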

Compound 3, half-maximal inhibitory concentration: > 100000 nM
Compound 3 ended at the assay's limit; the forecaster's own chance of this, stated with the estimate: 15%; at least 8.3-fold (0.92 log units) between middle value and limit.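

Compound 3 reads as a limit of this assay, not as a number: the limit of > 100000 nM in this assay, at which 1 of the 3 values shown sits. At this position, propyl in place of hydrogen on a saturated chain carbon, five bonds along the chain from an oxygen next to a carbonyl group, gives an at least 18-fold higher number from compound 2 to compound 3 (1.27 log units; beyond the scatter), a large step where the earlier butyl change was only modest. Taken from the methyl ester, the change gives an at least 61-fold higher number from compound 1 to compound 3 (1.79 log units; beyond the scatter), so across these three esters the number rises with each longer chain, and the last extension weighs far more than the first.

The compounds shown leave open whether the rise is gradual or sets in sharply at one chain length, which a hexyl or heptyl ester would show. Also open, going by these compounds, is how a carboxylic acid or an amide in place of the ester would read.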